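Cytotoxicity of three guanine analogues and a butylamino variant

This account rests on a few compounds, and the source may have more. Where it says the series, first, only, none or still open, it means among the compounds named here.

Compound 1 `COCCOc1nc(N)nc2c1ncn2/C=C1/CC1(CO)CO`: > 20000 nM in an ADME assay on Akata cells (Homo sapiens) for cytotoxicity, with a stated time of 7 days (a lower number here means that less compound is tolerated, a higher number that more compound is tolerated), a limit of the assay.
Compound 2 `CC(C)CNc1nc(N)nc2c1ncn2/C=C1/CC1(CO)CO`: > 24000 nM in this assay, a limit of the assay.
Compound 3 `CCCCCCSc1nc(N)nc2c1ncn2/C=C1/CC1(CO)CO`: > 20000 nM in this assay, a limit of the assay.

None of the three measured compounds gives a number in this assay; each reading is a limit, meaning the cells tolerated the highest concentration tested. Compound 1 therefore stands only at the limit of > 20000 nM in this assay, at which 2 of the 3 values shown sit, and no true value for it is known.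

Compound 4 `CCCCNc1nc(N)nc2c1ncn2/C=C1/CC1(CO)CO` differs from compound 1 in one place: butylamino in place of 2-methoxyethoxy on an aromatic carbon.

Within the data shown here, two measured steps bear on this change. The step that the two limits leave unreadable from compound 1 to compound 2 puts a branched amino chain in the same place, and the step that the two limits leave unreadable from compound 1 to compound 3 puts a sulfur-linked chain there; both begin and end at a limit, so neither has a readable size. A similar outcome is expected for compound 4: it is estimated at 25000 nM in this assay, within 12000 nM to 60000 nM. This expected result corresponds to a step that the limit leaves unreadable from compound 1 to compound 4, most likely again reported only as a limit.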

Compound 4, half-maximal cytotoxic concentration: > 24000 nM
Compound 4: only a limit was reported; the forecaster's own chance of this, stated with the estimate: 85%; the middle value lies beyond the limit too.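

Compound 4 gives only a limit in this assay, as do compound 1, compound 2 and compound 3, so none of its steps to those three can be read. The compounds shown leave open whether these different chains change the true cytotoxic concentration at all.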